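This account rests on a few compounds, and the source may have more. Where it says the series, first, only, none or still open, it means among the compounds named here.

In an ADME assay on L6 cells (Rattus norvegicus) for cytotoxicity, read by resazurin assay, with a stated time of 70 h (on this read-out higher numbers stand for weaker inhibition and lower numbers for stronger inhibition), three compounds sharing one core have been measured. Compound 1 `CC(=O)Oc1ccc2c(c1)C(C)=CC(C)(C)N2Cc1ccccc1` gives 24000 nM. Compound 2 `COc1cc(OC)cc(C(=O)Oc2ccc3c(c2)C(C)=CC(C)(C)N3Cc2ccc(C)cc2)c1` gives > 200000 nM, which is a limit of the assay and not a number. Compound 3 `CC1=CC(C)(C)N(Cc2ccccc2)c2ccc(OC(=O)c3ccccc3)cc21` gives > 240000 nM, which is also only a limit. Compound 3 therefore has no exact place on the scale, and it can only be said to lie at the weak-inhibition end of the values shown.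

Compound 4 `CC1=CC(C)(C)N(Cc2ccccc2)c2ccc(OC(=O)C3CCCCC3)cc21` differs from compound 3 in one group: cyclohexyl in place of phenyl on a carbonyl carbon. In plain terms, this puts cyclohexyl in place of phenyl on a carbonyl carbon, so one six-membered ring replaces another.

Among the measured compounds shown here, one measured step bears on this change: an at least 10-fold higher number from compound 1 to compound 3 (1.00 log units; beyond the scatter). That step, beyond the scatter, put phenyl in place of methyl on the same kind of carbonyl carbon. It shows that this group can matter, but it is a much larger change, and its size is known only as a bound. Swapping one ring for another should move the number less, so compound 4 is expected to remain at high numbers. The expected change is an at least 1.6-fold lower number from compound 3 to compound 4 (0.20 log units; that floor lies within the scatter), a modest move toward a lower number, and the assay may again report only a limit. For compound 4, the estimated value is 150000 nM, with an expected range of 45000 nM to 320000 nM.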

Compound 4, half-maximal inhibitory concentration: > 230000 nM
Compound 4 gave a limit, no number (the forecaster's own chance of this, stated with the estimate: 50%); middle value at least 1.5-fold (0.18 log units) from the limit.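

In this assay compound 4 reads > 230000 nM, which is a limit of the assay and not a number. Putting cyclohexyl in place of methyl on the carbonyl carbon gives an at least 9.5-fold higher number from compound 1 to compound 4 (0.98 log units; beyond the scatter), so the rise already seen with phenyl does not need an aromatic ring at this place. Compound 3 and compound 4 both carry only limits, and the step between them cannot be read, so this result gives no ranking of the two six-membered rings.

Still open, from the compounds shown here alone, is where, between the methyl of compound 1 and the six-membered rings of compound 3 and compound 4, the number begins to climb, and whether the true values of those two ring compounds differ at all. An ethyl group or a longer chain such as butyl on the same carbonyl carbon, or a cyclohexyl ring carrying an amine or a carboxylic acid, could help settle this, but only a compound that reads below the limit of the assay would give a number to compare.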